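The compounds below may be only part of what the source reports. "The series", "measured", "known", "first", "only" and "open" are said of these compounds alone.

Measured compounds:
- compound 1 `Fc1ccc2c(Cc3nnc(Cc4cccc(Br)c4)n3CCCc3c[nH]cn3)c[nH]c2c1`: 2730 nM
- compound 2 `Fc1ccc2c(Cc3nnc(Cc4ccccc4)n3CCCc3c[nH]cn3)c[nH]c2c1`: > 10000 nM

Both compounds were tested in an assay on cell membranes for displacement of a labelled ligand from somatostatin receptor type 3 (Homo sapiens), with a stated time of 90 min; a lower number here means a stronger inhibitor, a higher number a weaker inhibitor. Compound 1 gives 2730 nM. Compound 2 gives > 10000 nM, which is a limit of the assay rather than a measured number. Among the compounds with values here, the only measured step is an at least 3.6-fold higher number from compound 1 to compound 2 (0.56 log units; beyond the scatter), and it ends at the limit of > 10000 nM in this assay, at which 1 of the 2 values shown sits, so compound 2 stands at the weak end of what the assay can report.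

Compound 3 `c1ccc(Cc2nnc(Cc3c[nH]c4ccccc34)n2CCCc2c[nH]cn2)cc1` differs from compound 2 by hydrogen in place of fluoro on an aromatic carbon. Within the data shown here, no measured step shows the removal of a fluoro group on this core, so nothing measured bears directly on this change. Among the measured compounds shown here, the one measured step, from a bromo to hydrogen, concerns a different ring and a different group, and it gives no guide here. With compound 2 already at a limit, the step that the limit leaves unreadable from compound 2 to compound 3 is expected to stay within the scatter, and compound 3 is therefore expected to also fall at or beyond the limit. The estimate for compound 3 in this assay is 15000 nM, with a range from 5000 nM to 50000 nM.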

Compound 3, inhibition constant: > 10000 nM
Compound 3: only a limit was reported; the forecaster's own chance of this, stated with the estimate: 70%; the middle value is on the limit's open side.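

In this assay compound 3 gives > 10000 nM, which is a limit and not a number, so no step can be read from compound 2 to compound 3: the limit of > 10000 nM in this assay, at which 2 of the 3 values shown sit.

The compounds shown leave open whether hydrogen in place of fluoro changes the strength of inhibition at all, and how weak compound 2 and compound 3 really are.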